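This account rests on a few compounds, and the source may have more. Where it says the series, first, only, none or still open, it means among the compounds named here.

In a functional assay on MDA-MB-435 cells (Homo sapiens) for cytotoxicity, read by MTT assay, with a stated time of 48 h (on this read-out lower numbers stand for an effect already at smaller amounts and higher numbers for an effect only at larger amounts of compound), compound 1 (`CO[C@H]1O[C@H](COc2ccc3c(c2)CCCC3)[C@@H](O)[C@H](O)[C@H]1Oc1ccc(OC2CCCCC2)cc1`) gives 26000 nM as its only numerical result. Compound 2 (`CO[C@@H]1O[C@H](COc2ccc3c(c2)CCCC3)[C@@H](O)[C@H](O)[C@H]1Oc1ccc(OC2CCCCC2)cc1`) stands at "not determined" (no result reported) and so has no place on the scale. Compound 1 remains the nearest guide, given the fact that compounds 1 and 2 differ only in the configuration as drawn between the pair. Compound 3 (`CO[C@@H]1O[C@H](COc2ccc(-c3ccccc3)cc2)[C@@H](O)[C@H](O)[C@H]1Oc1ccc(OC2CCCCC2)cc1`) is the next to be tested. It is reached by one change, 4-phenylphenyl in place of 1,2,3,4-tetrahydronaphthalen-6-yl on an oxygen on a saturated carbon in the structure, with 4-phenylphenyl in place of 1,2,3,4-tetrahydronaphthalen-6-yl on an oxygen on a saturated carbon. No step beyond the scatter is expected from this change in this assay in either direction. Compound 3 is expected to give about 22000 nM in this test, with an estimated range from 8000 nM to 60000 nM overall.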

Compound 3, half-maximal effective concentration: 26000 nM
Compound 3: middle estimate off by 1.2-fold (0.07 log units), on the low side, within the range that was stated.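

Among these compounds, compound 2 has no number in this assay, so no step to compound 3 can be read. The compounds shown leave open what 4-phenylphenyl in place of 1,2,3,4-tetrahydronaphthalen-6-yl does on its own, and what the configuration does.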